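A few compounds are considered here, and "the series" means these few. Any claim that something is new, unique, unknown or untested is made for them only; others in the source may bear on it.

Three measured compounds and one still unmeasured share a common core, and they differ at only two places. Compound 3 `O=C(Nc1cccc(-n2cc(-c3ccncc3)c(-c3ccc(Cl)c(O)c3)n2)c1)Nc1ccc(Cl)c(Cl)c1` carries a 3,4-dichlorophenyl on an amide-type nitrogen and a hydroxy on the other aryl ring; in a functional assay on A498 cells (Homo sapiens) for inhibition, read by sulforhodamine B assay, with a stated time of 48 h (a lower number here means a stronger inhibitor of growth, a higher number a weaker inhibitor of growth), compound 3 gives 3170 nM. Compound 2 `COc1cc(-c2nn(-c3cccc(NC(=O)Nc4ccc(Cl)c(Cl)c4)c3)cc2-c2ccncc2)ccc1Cl` differs from compound 3 by methyl in place of hydrogen on an oxygen on an aromatic ring, and in this assay compound 2 gives 4590 nM; the step of a 1.4-fold lower number from compound 2 to compound 3 (0.16 log units; within the scatter) is small. Compound 1 `O=C(Nc1cccc(-n2cc(-c3ccncc3)c(-c3ccc(Cl)c(O)c3)n2)c1)Nc1cccc(C(F)(F)F)c1` differs from compound 3 by 3-(trifluoromethyl)phenyl in place of 3,4-dichlorophenyl on an amide-type nitrogen. In this assay compound 1 reaches only a limit, > 32500 nM, which is the limit of > 32500 nM in this assay, at which 1 of the 3 values shown sits. The step of an at least 10-fold higher number from compound 3 to compound 1 (1.01 log units; beyond the scatter) therefore points to a large loss of growth inhibition on exchanging the aryl on the amide-type nitrogen.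

Compound 4 `COc1cc(-c2nn(-c3cccc(NC(=O)Nc4cccc(C(F)(F)F)c4)c3)cc2-c2ccncc2)ccc1Cl` stands to compound 2 as compound 1 stands to compound 3, with 3-(trifluoromethyl)phenyl in place of 3,4-dichlorophenyl on an amide-type nitrogen; the place of the change is described in the same words in both cases, so it is the same change. The step is expected to be an 8.7-fold higher number from compound 2 to compound 4 (0.94 log units; beyond the scatter), because the same change gave an at least 10-fold higher number from compound 3 to compound 1 (1.01 log units; beyond the scatter). Compound 4 is thus estimated at 40000 nM, most likely between 15000 nM and 110000 nM.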

Compound 4, concentration for total growth inhibition: 4040 nM
Beside the measured number, compound 4's estimate is 9.9-fold (1.00 log units) above it; the whole stated range lies above it.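

In this assay, 3-(trifluoromethyl)phenyl in place of 3,4-dichlorophenyl on an amide-type nitrogen gives a 1.1-fold lower number from compound 2 to compound 4 (0.06 log units; within the scatter), so the large loss seen with the hydroxy group did not carry over to the core with the methyl on the oxygen: the same change on two cores in this assay, an at least 10-fold higher number (1.01 log units; beyond the scatter) from compound 3 to compound 1 and a 1.1-fold lower number (0.06 log units; within the scatter) from compound 2 to compound 4, at least 11-fold (1.06 log units) apart, beyond the scatter of two such steps Seen from the other place of change, methyl in place of hydrogen on an oxygen on an aromatic ring gives an at least 8.0-fold lower number from compound 1 to compound 4 (0.90 log units; beyond the scatter), which likewise differs from the step seen with the 3,4-dichlorophenyl group: the same change on two cores in this assay, a 1.4-fold lower number (0.16 log units; within the scatter) from compound 2 to compound 3 and an at least 8.0-fold higher number (0.90 log units; beyond the scatter) from compound 4 to compound 1, at least 11-fold (1.06 log units) apart, beyond the scatter of two such steps The value of compound 1, > 32500 nM, is a limit and not a number, so these four compounds show that the two changes depend on each other here but not how large the gap truly is, nor why it arises.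

The compounds shown leave open whether this dependence extends to other groups, such as an amine or a carboxylic acid on the aryl ring on the amide-type nitrogen. They also leave open what a longer chain in place of the methyl on the oxygen would give.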